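Homologating the Acetamide: Expected Clearance of Compound 4

The source may hold more compounds than are shown below. What is called first, only, known or untested is meant among the compounds shown, and "the series" means these compounds.

Compound 2 `CC1c2cc(Cl)ccc2C(=O)N1c1cccnc1` and compound 1 `CCC1c2cc(Cl)ccc2C(=O)N1c1cccnc1` share one core and differ by methyl in place of hydrogen on a saturated chain carbon bound to a saturated ring carbon. In an ADME assay on microsomes from liver (Mus musculus) for metabolic stability, read by LC-MS, using NADPH, with stated times of 10 min and 30 min (a higher number here means faster removal of the compound, a lower number slower removal), compound 2 gives 66.5 mL/min/kg. In this assay compound 1 gives 65.9 mL/min/kg. The step between them is a 1.0-fold lower number from compound 2 to compound 1 (0.00 log units; within the scatter).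

Compound 3 `CC(=O)N[C@@H]1CCCc2c1cncc2N1Cc2cc(Cl)ccc2C1=O` is built on another core; the difference between the two cores is not broken down here. In this assay compound 3 gives < 20.2 mL/min/kg, which is a limit of the assay and not a number, as noted in the limit of < 20.2 mL/min/kg in this assay, at which 1 of the 3 values shown sits.

Compound 4 `CCC(=O)N[C@@H]1CCCc2c1cncc2N1Cc2cc(Cl)ccc2C1=O` differs from compound 3 by methyl in place of hydrogen on a saturated chain carbon bound to a carbonyl carbon. Among the compounds with values here, this is the same kind of change as the one from compound 2 to compound 1, though not the same: there the chain carbon is bound to a saturated ring carbon, here to a carbonyl carbon. Compound 4 is expected to show a step that the limit leaves unreadable from compound 3 to compound 4 in this assay because the earlier step of a 1.0-fold lower number from compound 2 to compound 1 (0.00 log units; within the scatter) lay within the scatter. Compound 4 is therefore estimated at 15 mL/min/kg, between 8 mL/min/kg and 30 mL/min/kg, and the assay may again report only a limit.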

Compound 4, clearance: < 20.2 mL/min/kg
Compound 4 gave a limit, no number (the forecaster's own chance of this, stated with the estimate: 60%); the middle value is on the limit's open side.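

In this assay compound 4 gives < 20.2 mL/min/kg, which is a limit of the assay and not a number. Compound 3 also stands at a limit, so no step can be read from compound 3 to compound 4: the limit of < 20.2 mL/min/kg in this assay, at which 2 of the 4 values shown sit.

The compounds shown leave open how large any difference in clearance between acetamido and propanoylamino is on this core.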